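Benzyl ring substitution and maximal response in this series

This account rests on a few compounds, and the source may have more. Where it says the series, first, only, none or still open, it means among the compounds named here.

a functional assay on the whole organism (B cells) with Mus musculus as the target (a higher number here means a larger maximal response, a lower number a smaller maximal response), covers three measured compounds. Compound 1 `NCC(O)Cn1c(=O)n(C2OC(CO)[C@@H](O)[C@H]2O)c2nc(N)nc(O)c21` gives 110%, compound 2 `Nc1nc(O)c2c(n1)n(C1OC(CO)[C@@H](O)[C@H]1O)c(=O)n2Cc1ccc(Cl)cc1` gives 15%, and compound 3 `COc1ccc(Cn2c(=O)n(C3OC(CO)[C@@H](O)[C@H]3O)c3nc(N)nc(O)c32)cc1` gives 44%; compound 3 thus stands second highest of the three, with compound 2 below it and compound 1 above it, both gaps beyond the scatter. Compound 4 `Nc1nc(O)c2c(n1)n(C1OC(CO)[C@@H](O)[C@H]1O)c(=O)n2Cc1ccccc1` differs from compound 3 by hydrogen in place of methoxy on an aromatic carbon. Among the compounds with values here, the only measured step on the aromatic ring of the benzyl group is a number 29 percentage points higher from compound 2 to compound 3 (beyond the scatter), a modest change. Within the data shown here, no measured step replaces a ring substituent with hydrogen, so the direction rests on the two ring-substituted values alone. A downward, modest step of a number 14 percentage points lower from compound 3 to compound 4 (beyond the scatter) is estimated. Compound 4 is therefore expected to give 30%, within 10% to 60%.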

Compound 4, largest response reached (reported as maximal response), in percent of the reference or control that the assay uses: 110%
Estimate against measurement, compound 4: 80 percentage points below; measured number above the stated range.
By their numbers in this assay, from the lowest: compound 2; then compound 3; then compounds 1 and 4 (each within the scatter of the next).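

Removing the ring substituent restores the response in this assay: there is a number 66 percentage points higher from compound 3 to compound 4 (beyond the scatter) and a number 95 percentage points higher from compound 2 to compound 4 (beyond the scatter). Hydrogen thus gives a higher number here than either methoxy or chloro, so the low numbers of compound 2 and compound 3 go with these ring substituents and not with the benzyl group itself. Against the 2-amino-1-hydroxyethyl chain, phenyl shows no change at the digits printed from compound 1 to compound 4 (within the scatter), so an unsubstituted benzyl group is tolerated at this nitrogen.

Going by these compounds, whether fluoro, an amine or a carboxylic acid on the same ring carbon also lowers the number remains open. No measurement shown here explains the losses with methoxy and chloro.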